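The source may hold more compounds than are shown below. What is called first, only, known or untested is meant among the compounds shown, and "the series" means these compounds.

Compound 1, `Cc1cccc2nc(-c3cccc(NC(=O)CCCc4ccccc4)c3)[nH]c12`, gives 38600 nM.
Compound 2, `O=C(CCCc1ccccc1)Nc1cccc(-c2nc3ccccc3[nH]2)c1`, gives 43000 nM.
Compound 3, `O=C(CCc1ccccc1)Nc1ccc(-c2nc3ccccc3[nH]2)cc1`, gives 29000 nM.

All three were tested in an assay on cells for inhibition of matrix metalloproteinase-9 (Homo sapiens), read by fluorescence, with stated times of 15 min and 4 h; a higher number here means a weaker inhibitor, a lower number a stronger inhibitor. Compound 2 and compound 1 differ in one place: methyl in place of hydrogen on an aromatic carbon. That change gave a 1.1-fold lower number from compound 2 to compound 1 (0.05 log units; within the scatter), so it left the inhibition essentially unchanged. Compound 3 differs from compound 2 in more than a single spot, and the difference between the two cores is not broken down here; its number and those of compound 1 and compound 2 all lie within the scatter of one another, so no order can be read among them.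

Compound 4, `Cc1ccc2nc(-c3ccc(NC(=O)CCc4ccccc4)cc3)[nH]c2c1`, has not yet been measured. It differs from compound 3 in one place: methyl in place of hydrogen on an aromatic carbon. This is the same kind of change as that from compound 2 to compound 1, not the same change, since in compound 1 the methyl sits ortho to a fused ring and meta to a fused ring, whereas in compound 4 it sits meta to a fused ring and para to a fused ring. Because a 1.1-fold lower number from compound 2 to compound 1 (0.05 log units; within the scatter) fell within the scatter, a similarly small step is expected here: a 1.1-fold lower number from compound 3 to compound 4 (0.03 log units; within the scatter). Compound 4 is therefore estimated at 27000 nM, expected to lie between 12000 nM and 60000 nM.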

Compound 4, half-maximal inhibitory concentration: 60000 nM
Compound 4: middle estimate off by 2.2-fold (0.35 log units), on the low side; low and high end bracket the measured number.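

In this assay, methyl in place of hydrogen on an aromatic carbon gave a 2.1-fold higher number from compound 3 to compound 4 (0.32 log units; beyond the scatter), a modest weakening of inhibition on this core. Set beside the earlier step on the other core, this result looks different, but the gap between the two steps is not large enough to count as a real difference: the same change on two cores in this assay, a 1.1-fold lower number (0.05 log units; within the scatter) from compound 2 to compound 1 and a 2.1-fold higher number (0.32 log units; beyond the scatter) from compound 3 to compound 4, 2.3-fold (0.36 log units) apart, within the scatter of two such steps. The data therefore do not show that the methyl behaves differently on the two cores, nor do they prove that it behaves the same, and with one pair per core and the methyl at a different place in compound 1 and compound 4, no rule for carrying this change across the series can be drawn.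

The compounds shown leave open whether moving the methyl to another carbon on the same core would change the outcome. Also open, from the compounds shown here alone, is whether an amine or a carboxylic acid on that aromatic carbon would shift the number more clearly in either direction.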